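The compounds below may be only part of what the source reports. "The series", "measured", "known", "first", "only" and "open" are said of these compounds alone.

Measured in a functional assay on Raji cells (Homo sapiens) for cytotoxicity, with a stated time of 72 h (a lower number here means that less compound is needed, a higher number that more compound is needed for the effect), each reading a limit:
- Compound 1 `C=C[C@@](C)(/C=C/c1ccc(O)c(/C=C/C(=O)OCC)c1)CCC=C(C)C`: > 26000 nM
- Compound 2 `C=C[C@@](C)(/C=C/c1ccc(O)c(/C=C/c2ccc(F)cc2)c1)CCC=C(C)C`: > 26000 nM
- Compound 3 `C=C[C@@](C)(/C=C/c1ccc(O)c(/C=C/c2ccc(Cl)cc2)c1)CCC=C(C)C`: > 26000 nM

Compound 3 has no numerical value, only the limit > 26000 nM. The same holds across the series, as the limit of > 26000 nM in this assay, at which 3 of the 3 values shown sit, shows, so compound 3 cannot be placed relative to compound 1 or compound 2.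

Compound 4 `C=C[C@@](C)(/C=C/c1ccc(O)c(/C=C/C=C/c2ccccc2)c1)CCC=C(C)C` has 2-phenylethenyl in place of 4-chlorophenyl on a double-bonded chain carbon bound to a double-bonded chain carbon. Two measured steps change the same place: a step that the two limits leave unreadable from compound 1 to compound 2 and a step that the two limits leave unreadable from compound 1 to compound 3. A third, a step that the two limits leave unreadable from compound 2 to compound 3, changes only the halogen on the aromatic carbon. None of the three has a readable size, so they offer no measured size or direction to carry over to compound 4.

In this assay, the expectation is therefore no clear step in either direction, and compound 4 may well return only a limit too. The expected change is a step that the limit leaves unreadable from compound 3 to compound 4, an estimate with wide uncertainty. For compound 4 the estimated value is 30000 nM, with an expected range of 12000 nM to 70000 nM.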

Compound 4, half-maximal effective concentration: > 26000 nM
Compound 4 gave a limit, no number; the forecaster's own chance of this, stated with the estimate: 75%; the middle value is on the limit's open side.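

In this assay compound 4 gives only a limit, > 26000 nM. Its steps from compound 1, compound 2 and compound 3 therefore cannot be read. The compounds shown leave open whether any change at this place on the shared core alters the read-out, because all the readings stop at one limit: the limit of > 26000 nM in this assay, at which 4 of the 4 values shown sit.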